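The source may report more compounds than this note shows. Statements on the series, on what has been measured and on what is new or still open speak of the compounds shown alone.

Working notes on the series:

- Compound 1 `COc1ccc2[nH]cc(/C=C(\C#N)C(=O)c3c[nH]c4ccccc34)c2c1`: 30500 nM
- Compound 2 `N#C/C(=C\c1cn(Cc2ccc(Cl)cc2)c2ccc(Br)cc12)C(=O)c1c[nH]c2ccccc12`: 36500 nM
- Compound 3 `COc1ccc2[nH]cc(/C=C(\C#N)C(=O)c3c[nH]c4ccc(OC)cc34)c2c1`: not yet measured

In a functional assay on PC-3 cells (Homo sapiens) for cytotoxicity, read by WST assay, with a stated time of 48 h (a lower number here means a stronger inhibitor, a higher number a weaker inhibitor), compound 1 gives 30500 nM and compound 2 gives 36500 nM. Among the compounds with values here, these two values lie within the scatter of each other, so compound 1 stands level with the only other measured compound. Compound 3 keeps the core of compound 1 and carries methoxy in place of hydrogen on an aromatic carbon. Within the data shown here, no measured pair differs in one place, so the data give no direct guide to this change. No shift beyond the scatter is expected in this assay, in either direction. The estimated move is a 1.1-fold lower number from compound 1 to compound 3 (0.04 log units; within the scatter). The expected value for compound 3 is 28000 nM, with an estimated range of 10000 nM to 70000 nM.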

Compound 3, half-maximal inhibitory concentration: > 50000 nM
Compound 3 was reported as a limit; the forecaster's own chance of this, stated with the estimate: 20%; at least 1.7-fold (0.25 log units) between middle value and limit.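

In this assay the series now has its first step in one place, which reads an at least 1.6-fold higher number from compound 1 to compound 3 (0.21 log units; that floor lies within the scatter) for methoxy in place of hydrogen on an aromatic carbon, meta to a fused ring and para to a fused ring. Compound 3 stands at a limit of the assay, not at a number: the limit of > 50000 nM in this assay, at which 1 of the 3 values shown sits. This step shows no gain from methoxy at this position, and since only its floor is known, the true size of the change remains undefined.

Going by these compounds, whether fluorine, an amine or a carboxylic acid at this position would read differently from methoxy stays open. Also open, on these data alone, is whether methoxy here would behave the same way on the core of compound 2, which differs from compound 1 in more than one place.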